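Removal of the N-acyl group in a tetrahydroquinoline anilide series

A few compounds are considered here, and "the series" means these few. Any claim that something is new, unique, unknown or untested is made for them only; others in the source may bear on it.

Measured so far:
compound 1, `O=C(Nc1ccccc1O)C1CCc2ccccc2N1C(=O)c1ccccc1Cl`: 60000 nM
compound 2, `O=C(Nc1ccc(C(F)(F)F)cc1)C1CCc2ccccc2N1`: 20300 nM
compound 3, `CCC(=O)N1c2ccccc2CCC1C(=O)Nc1cc(C(F)(F)F)cc(C(F)(F)F)c1`: 8540 nM

In a functional assay on PC-3 cells (Homo sapiens) for cytotoxicity, read by sulforhodamine B assay, with a stated time of 72 h (a higher number here means a weaker inhibitor of growth, a lower number a stronger inhibitor of growth), compound 1 gives the highest of the three numbers; compound 2 gives a lower number, and compound 3 gives a lower number still, both beyond the scatter. For the measured compounds named here, compounds 2 and 3 differ from compound 1 in more than one place, so no single step between measured compounds is available, and what they show is only that the unacylated nitrogen of compound 2 and the propanoyl nitrogen of compound 3 both sit with lower numbers than compound 1.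

Compound 4, `O=C(Nc1ccccc1O)C1CCc2ccccc2N1`, is the next compound to be measured in this assay. It differs from compound 1 by hydrogen in place of (2-chlorophenyl)carbonyl on a nitrogen on an aromatic ring in a ring. The change mirrors, in part, the distinction between compound 1 and compound 2, whose value of 20300 nM is lower, but the anilide part of compound 4 is that of compound 1, not that of compound 2, so the comparison is indirect.

The step from compound 1 to compound 4 is expected to be small, a 1.5-fold lower number from compound 1 to compound 4 (0.18 log units; within the scatter), and possibly not beyond the scatter. Compound 4 is estimated at 40000 nM, with a range of 12000 nM to 130000 nM.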

Compound 4, concentration for 50% growth inhibition: 4310 nM
Compound 4: middle estimate off by 9.3-fold (0.97 log units), on the high side; measured number outside the range, below it.
By their numbers in this assay, from the lowest: compounds 4 and 3 (each within the scatter of the next); then compound 2; then compound 1.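

In this assay, for the compounds shown here, replacing the (2-chlorophenyl)carbonyl on the ring nitrogen with hydrogen gives a 14-fold lower number from compound 1 to compound 4 (1.14 log units; beyond the scatter) and is the first step that changes only one place. With the anilide part held constant, the (2-chlorophenyl)carbonyl group is not required for growth inhibition in these cells, and the unsubstituted nitrogen of compound 4 gives the much lower number. This holds for this pair alone, and it does not show whether the same step would be seen with another anilide part.

As far as these compounds go, it remains open whether the higher number of compound 1 depends on acylation of this nitrogen as such or on this particular group, which a plain benzoyl without the chlorine, a small acetyl or a simple methyl on the same nitrogen of compound 4 would help to separate. No measurement at hand accounts for the size of this step, so its cause remains unassigned.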